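A few compounds are considered here, and "the series" means these few. Any claim that something is new, unique, unknown or untested is made for them only; others in the source may bear on it.

The measured compounds:

Compound 1, `Nc1nc(N)c2nc(Nc3ccc(O)cc3)ccc2n1`, gives 1580 nM in an ADME assay on isolated protein for inhibition of Dihydrofolate reductase (Homo sapiens), using NADPH; on this read-out higher numbers stand for weaker inhibition and lower numbers for stronger inhibition.
Compound 2, `Nc1nc(N)c2nc(Nc3cc(F)c(F)c(F)c3)ccc2n1`, gives 1810 nM in this assay.
Compound 3, `CCCN(c1ccccc1)c1ccc2nc(N)nc(N)c2n1`, gives 1340 nM in this assay.

The three numbers lie close together. Compound 3 sits at the low end of them, but its gap to compound 1 and its gap to compound 2 each fall within the usual scatter of this kind of measurement, so none of the three can be set apart from the others on these numbers alone.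

Compound 4, `CCN(c1ccccc1)c1ccc2nc(N)nc(N)c2n1`, has not yet been measured in this assay. It differs from compound 3 in one place: hydrogen in place of methyl on a saturated chain carbon, two bonds along the chain from a nitrogen on an aromatic ring, so the propyl on the ring nitrogen becomes an ethyl. Among the compounds with values here, no measured pair in this set shares such a step, so there is no direct guide to its size. Given that compound 3 gives 1340 nM and the change removes only one saturated chain carbon, the step of a 1.1-fold higher number from compound 3 to compound 4 (0.05 log units; within the scatter) is expected to stay within the scatter, with no clear direction. Compound 4 is therefore estimated at 1500 nM, within a range from 700 nM to 3200 nM.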

Compound 4, half-maximal inhibitory concentration: 1570 nM
Estimate against measurement, compound 4: 1.0-fold (0.02 log units) below; the range from low to high includes it.
By their numbers in this assay, from the lowest: compounds 3, 4, 1 and 2 (each within the scatter of the next).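

In this assay, within the data shown here, the change from propyl to ethyl on the ring nitrogen gives a 1.2-fold higher number from compound 3 to compound 4 (0.07 log units; within the scatter), the only step here between two measured compounds that differ in one place. Among these compounds, it shows that, for this one pair, removing the methyl on this saturated chain carbon produces no change that can be told from the scatter, something the earlier compounds, which differed in more than one place, could not show. Nothing measured here bears on why this is so.

The compounds shown leave open whether a longer chain such as butyl or a branched one such as isopropyl on this nitrogen would also stay within the scatter of compound 3. They also leave open what an amine or a hydroxyl in place of this methyl would do.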